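Replacing a Thiazoline Substituent in a Gastric Cancer Cell Series

The source may hold more compounds than are shown below. What is called first, only, known or untested is meant among the compounds shown, and "the series" means these compounds.

Compound 1 `COc1ccc(C2=NN(C3=NC(c4ccccc4)CS3)C(c3cccc4ccccc34)C2)cc1` gives 9510 nM in a functional assay on BGC-823 cells (Homo sapiens) for inhibition, read by CCK-8 assay, with a stated time of 48 h; on this read-out lower numbers stand for stronger inhibition and higher numbers for weaker inhibition.
Compound 2 `Cc1ccc(C2=NN(C3=NC(c4ccccc4)CS3)C(c3cccc4ccccc34)C2)cc1C` gives 8460 nM in this assay.

Among the compounds with values here, compound 1 stands highest of the two numbers in this assay, with compound 2 nearest; the only measured step, a 1.1-fold lower number from compound 1 to compound 2 (0.05 log units; within the scatter), changes the aryl group on the carbon with a double bond to nitrogen and leaves the two compounds within the scatter of each other.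

Compound 3 `COc1ccc(C2=NN(C3=NC(=O)CS3)C(c3cccc4ccccc34)C2)cc1` is not yet measured. It differs from compound 1 by a group of 6 heavy atoms (3 carbon, 1 nitrogen, 1 oxygen, 1 sulfur; one five-membered non-aromatic ring with 2 hetero atoms) in place of a group of 11 heavy atoms (9 carbon, 1 nitrogen, 1 sulfur; one five-membered non-aromatic ring with 2 hetero atoms, one six-membered aromatic ring of carbon only), on an amine nitrogen in a ring — in words, a group of 6 heavy atoms (3 carbon, 1 nitrogen, 1 oxygen, 1 sulfur; one five-membered non-aromatic ring with 2 hetero atoms) in place of a group of 11 heavy atoms (9 carbon, 1 nitrogen, 1 sulfur; one five-membered non-aromatic ring with 2 hetero atoms, one six-membered aromatic ring of carbon only), on an amine nitrogen in a ring.

Within the data shown here, no measured step touches this part of the shared core; the single step from compound 1 to compound 2 concerns a different position and was within the scatter. There is therefore no measured basis for a direction, and the expectation for compound 3 rests on compound 1 alone, with a wide range. The step from compound 1 to compound 3 is estimated as a 1.3-fold higher number from compound 1 to compound 3 (0.10 log units; within the scatter). Compound 3 is expected to give about 12000 nM in this assay, with an estimated range from 3500 nM to 40000 nM.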

Compound 3, half-maximal inhibitory concentration: 8210 nM
Compound 3: middle estimate off by 1.5-fold (0.16 log units), on the high side; measured number inside the range.
By their numbers in this assay, from the lowest: compounds 3, 2 and 1 (each within the scatter of the next).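

In this assay, placing the group of 6 heavy atoms on the amine nitrogen in a ring, where compound 1 carries the group of 11 heavy atoms, gives a 1.2-fold lower number from compound 1 to compound 3 (0.06 log units; within the scatter). Within the data shown here, this is the first sign that this position tolerates a large change in the group it carries: the six-membered aromatic ring of carbon only is lost and an oxygen and a second double bond outside aromatic rings are gained, yet the numbers stay within the scatter of each other, so the aromatic ring is not required to keep a number of this size in this assay. No measured information on the compounds explains why the exchange leaves the number where it is.

What the compounds shown leave open is whether any group on this nitrogen can move the number beyond the scatter, since all three remain close together, and a thiazoline ring bearing a carboxylic acid, an amine or a longer chain might behave differently. They also leave open how the naphthalen-1-yl group contributes, as no step shown replaces it, for example with a simple phenyl group.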